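The source may hold more compounds than are shown below. What is called first, only, known or untested is meant among the compounds shown, and "the series" means these compounds.

Measured so far in an assay on LtK cells with ATP-sensitive inward rectifier potassium channel 11 (Homo sapiens) as the target; on this read-out lower numbers stand for an effect already at smaller amounts and higher numbers for an effect only at larger amounts of compound:
- compound 1 `CCCC(=O)Nc1c(C(O)(C(F)(F)F)C(F)(F)F)ccc2ccccc12`: 131 nM
- compound 2 `O=C(Nc1c(C(O)(C(F)(F)F)C(F)(F)F)ccc2ccccc12)C1CC1`: 751 nM
- compound 3 `O=C(Nc1c(C(O)(C(F)(F)F)C(F)(F)F)ccc2ccccc12)c1ccc(F)cc1`: 70 nM

Among the compounds with values here, compound 3 stands at the lowest of the three numbers, but its gap to compound 1 lies within the scatter, so the two cannot be ordered; only the step of an 11-fold lower number from compound 2 to compound 3 (1.03 log units; beyond the scatter) is large. Among the other steps, a 1.9-fold lower number from compound 1 to compound 3 (0.27 log units; within the scatter) is within the scatter, while a 5.7-fold higher number from compound 1 to compound 2 (0.76 log units; beyond the scatter) is modest. All three steps exchange the whole group on the carbonyl carbon.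

Compound 4 `Cc1ccc(C(=O)Nc2c(C(O)(C(F)(F)F)C(F)(F)F)ccc3ccccc23)cc1` differs from compound 3 in one place: methyl in place of fluoro on an aromatic carbon. Within the data shown here, no measured step touches a substituent on the aromatic ring of the carbonyl group, so none bears directly on this change; the measured steps only show that a 4-fluorophenyl on the carbonyl carbon sits at the low end of the series. With no guide, the expected step of a 1.1-fold higher number from compound 3 to compound 4 (0.06 log units; within the scatter) is taken as none beyond the scatter. The estimate for compound 4 in this assay is 80 nM, expected to fall between 30 nM and 220 nM.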

Compound 4, half-maximal effective concentration: 76 nM
Estimate against measurement, compound 4: 1.1-fold (0.02 log units) above; low and high end bracket the measured number.
By their numbers in this assay, from the lowest: compounds 3, 4 and 1 (each within the scatter of the next); then compound 2.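

In this assay, within the data shown here, a 1.1-fold higher number from compound 3 to compound 4 (0.04 log units; within the scatter), so on an aromatic carbon para to a large group, methyl and fluoro cannot be told apart, which is the first reading of any change at this place on the ring. The 4-methylphenyl group on the carbonyl carbon repeats the pattern seen with 4-fluorophenyl: a 9.9-fold lower number from compound 2 to compound 4 (0.99 log units; beyond the scatter), a gap that sets cyclopropyl apart, while a 1.7-fold lower number from compound 1 to compound 4 (0.24 log units; within the scatter), so compound 4 and compound 1 cannot be ordered. Nothing at hand explains why the exchange of methyl for fluoro leaves the number in place.

Open, as far as these compounds go, is whether an amine or a carboxylic acid at the same place on the ring would hold the number as methyl and fluoro do. Also open, from the compounds shown here alone, is whether a longer chain in place of propyl on the carbonyl carbon would stay with compound 1 or move towards compound 2.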